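This account rests on a few compounds, and the source may have more. Where it says the series, first, only, none or still open, it means among the compounds named here.

In a functional assay on HCT-116 cells (Homo sapiens) for antiproliferative activity, read by CCK-8 assay, with a stated time of 72 h (a lower number here means a stronger inhibitor, a higher number a weaker inhibitor), compound 1 (`COc1ccc(SCc2ccc(C(=O)Nc3ccccc3N)cc2)cc1`) gives 1640 nM. Going by the values given here, the only other measured compound, compound 2 (`COc1ccc(SCc2ccc(C(=O)Nc3ccccc3N)cc2)cc1OC`), gives 2000 nM, so compound 1 stands level with it. The compound still to be measured, compound 3 (`Nc1ccccc1NC(=O)c1ccc(CSc2ccc(Cl)cc2)cc1`), keeps the core of compound 1 and differs in one place: chloro in place of methoxy on an aromatic carbon. This is chloro in place of methoxy on an aromatic carbon, para to a large group, which reads as 4-methoxyphenyl to 4-chlorophenyl.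

Among the compounds with values here, only one measured step bears on this change, and it does so indirectly. It places a further methoxy in place of hydrogen on an aromatic carbon of the same ring, and it amounts to a 1.2-fold higher number from compound 1 to compound 2 (0.09 log units; within the scatter). Within the data shown here, no measured compound carries chloro, so the data offer no direct reading of this exchange. On this evidence, no step beyond the scatter is expected in this assay, and neither direction is favoured. The estimated change is small, a 1.1-fold lower number from compound 1 to compound 3 (0.04 log units; within the scatter). For compound 3 the expected value is 1500 nM, with an estimated range from 700 nM to 3200 nM.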

Compound 3, half-maximal inhibitory concentration: 3750 nM
Compound 3: the middle estimate sits 2.5-fold (0.40 log units) below what was measured; measured number outside the range, above it.
By their numbers in this assay, from the lowest: compounds 1, 2 and 3 (each within the scatter of the next, the first and the last beyond it).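

Exchanging 4-methoxyphenyl for 4-chlorophenyl in this assay gives a 2.3-fold higher number from compound 1 to compound 3 (0.36 log units; beyond the scatter), a modest step, but the only one among the compounds shown that lies beyond the scatter. The position para to a large group is therefore not indifferent to what it carries, a point the earlier pair could not show: adding a further methoxy to the same ring gives a 1.2-fold higher number from compound 1 to compound 2 (0.09 log units; within the scatter), which stays within the scatter. No measurement is available that gives a reason for the step from methoxy to chloro.

The compounds shown leave open whether the higher number goes with losing methoxy or with gaining chloro, and a single exchange at this place cannot separate the two readings. Also open, going by these compounds, is how this position would respond to fluoro, an amine, a carboxylic acid or a longer chain such as ethoxy, and whether any of these would match or improve on the number of compound 1 in this assay.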